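This account rests on a few compounds, and the source may have more. Where it says the series, first, only, none or still open, it means among the compounds named here.

Notes on the series. Compound 2 `COc1ccc(NC(=O)[C@@H]2Cc3ccc(OCC(=O)NO)cc3CN2C(=O)CNC(=O)OC(C)(C)C)cc1` gives 514 nM in an assay on isolated protein for inhibition of histone deacetylase 8 (Homo sapiens), read by fluorescence, with a stated time of 30 min (on this read-out lower numbers stand for stronger inhibition and higher numbers for weaker inhibition), and stands second highest of the three numbers; compound 1 `O=C(COc1ccc2c(c1)CN(C(=O)CCc1ccccc1)[C@H](C(=O)Nc1ccccc1)C2)NO` gives 759 nM, within the scatter of it, and compound 3 `COc1ccc(NC(=O)[C@@H]2Cc3ccc(OCC(=O)NO)cc3CN2C(=O)[C@H](CC(C)C)NC(=O)OC(C)(C)C)cc1` gives 163 nM. Among the measured compounds shown here, the only measured step, a 3.2-fold lower number from compound 2 to compound 3 (0.50 log units; beyond the scatter), concerns a different place on the shared core. Compound 4 `COc1ccc(NC(=O)[C@@H]2Cc3ccc(OCC(=O)NO)cc3CN2CCCc2ccccc2)cc1` carries 3-phenylpropyl in place of (((tert-butoxycarbonyl)amino)methyl)carbonyl on an amine nitrogen in a ring. For the measured compounds named here, no measured step bears directly on this change; compound 1 and compound 2, which also differ on the amine nitrogen in the ring, show numbers within the scatter of each other. The expectation for compound 4 is therefore a step of a 1.2-fold higher number from compound 2 to compound 4 (0.07 log units; within the scatter), not beyond the scatter. Compound 4 is estimated at 600 nM, with a range of 200 nM to 2000 nM.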

Compound 4, half-maximal inhibitory concentration: 1720 nM
For compound 4 the middle estimate is 2.9-fold (0.46 log units) below the measured one; the range from low to high includes it.
By their numbers in this assay, from the lowest: compound 3; then compounds 2 and 1 (each within the scatter of the next); then compound 4.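

Among the compounds shown here, at the amine nitrogen in the ring, the change gives a 3.3-fold higher number from compound 2 to compound 4 (0.52 log units; beyond the scatter), the first step beyond the scatter at this place. It removes a chain with two double bonds, one hydrogen-bond donor and three hydrogen-bond acceptors and brings in a carbon-only chain with an aromatic ring, so several features change together and this single step does not separate them. Nothing measured here accounts for the step. Open, on these data alone, is how a benzyl group or a free aminoacetyl group on this nitrogen would read in this assay, and which feature of the change the number follows.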